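The source may report more compounds than this note shows. Statements on the series, on what has been measured and on what is new or still open speak of the compounds shown alone.

Series notes, values in a functional assay on HepG2 cells (Homo sapiens) for cytotoxicity, read by MTT assay, with a stated time of 24 h; a lower number here means a stronger inhibitor, a higher number a weaker inhibitor:

- compound 1 `COc1ccc(Cc2cn3cc(Br)ccc3nc2=O)cc1` gives > 1000000 nM (a limit of the assay, not a number)
- compound 2 `Nc1cccn2cc(Cc3ccccc3)c(=O)nc12` gives 131000 nM
- compound 3 `O=C1N=C2C=CC=CN2CC1C(O)c1cccs1` gives > 1000000 nM (a limit of the assay, not a number)

Among the measured compounds shown here, compound 2 carries the only true number, at 131000 nM in this assay. The rest of the data is the limit of > 1000000 nM in this assay, at which 2 of the 3 values shown sit. For the measured compounds named here, these limits give no number to set against compound 2, and no pair of measured compounds differs in one place, so the series offers no measured step to use as a guide.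

The next compound is compound 4 `Nc1cccn2cc(Cc3ccc(F)cc3)c(=O)nc12`. It keeps the whole of compound 2 and carries one change on the benzyl-side ring: fluoro in place of hydrogen on an aromatic carbon. In words, this is fluoro in place of hydrogen on an aromatic carbon, para to a large group.

Going by the values given here, with no measured step for this kind of change, no direction can be argued from the data. The expectation is a step of no size beyond the scatter in this assay, so the starting point for compound 4 remains compound 2 at 131000 nM. The estimated change is a 1.1-fold lower number from compound 2 to compound 4 (0.04 log units; within the scatter). Among the compounds with values here, the range is kept wide because only one number anchors it. For compound 4 the expected value is 120000 nM, with an estimated range from 50000 nM to 350000 nM.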

Compound 4, half-maximal inhibitory concentration: > 1000000 nM
Compound 4: only a limit was reported; the forecaster's own chance of this, stated with the estimate: 12%; middle value at least 8.3-fold (0.92 log units) from the limit.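

Among the compounds shown here, the first measured step is an at least 7.6-fold higher number from compound 2 to compound 4 (0.88 log units; beyond the scatter), for fluoro in place of hydrogen on an aromatic carbon, para to a large group. For the compounds shown here, this shows that in this assay the position on the benzyl-side ring responds to a change of a single heavy atom, which the earlier compounds, with no pair differing in one place, could not show. The step has a floor but no upper end, and compound 2 stays the only compound with a true number, set apart from the others: the limit of > 1000000 nM in this assay, at which 3 of the 4 values shown sit.

From the compounds shown here alone, whether this step is specific to fluoro or would follow any replacement of hydrogen here stays open, and chloro, methyl or a nitrile in place of the fluoro would help separate those readings. The compounds shown also do not tell how far the number of compound 2 depends on its amino group, which an acetamide or a carboxylic acid in that place would test.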